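This account rests on a few compounds, and the source may have more. Where it says the series, first, only, none or still open, it means among the compounds named here.

Measured so far:
- Compound 1, `Cc1ccccc1NC(=O)N[C@H](C)c1ccccc1`: 100%
- Compound 2, `CCc1ccccc1NC(=O)N[C@H](C)c1ccccc1`: 101%
- Compound 3, `C[C@@H](NC(=O)Nc1ccccc1I)c1ccccc1`: 100%

In an ADME assay on the whole organism with Oryza sativa as the target, tested at 0.1 uM (a lower number here means a stronger effect, a higher number a weaker effect of the compound at the concentration tested), compound 1 stands level with compound 3 at the digits shown, the two together the lowest of the three numbers; its nearest neighbour is compound 3, no change at the digits printed from compound 1 to compound 3 (within the scatter), and its furthest is compound 2, a number 1 percentage points higher from compound 1 to compound 2 (within the scatter). Compound 4, `Cc1cc(F)ccc1NC(=O)N[C@H](C)c1ccccc1`, has not yet been tested. It differs from compound 1 in one place: fluoro in place of hydrogen on an aromatic carbon. Among the compounds with values here, no measured step adds a fluoro group, but the three changes made on the same aromatic ring, a number 1 percentage points higher from compound 1 to compound 2 (within the scatter), no change at the digits printed from compound 1 to compound 3 (within the scatter) and a number 1 percentage points lower from compound 2 to compound 3 (within the scatter), all stayed within the scatter. On that basis the expected step is no change at the digits printed from compound 1 to compound 4 (within the scatter), no change beyond the scatter. Compound 4 is therefore estimated at 100%, between 92% and 108%.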

Compound 4, a percentage reported as activity, at one concentration (the size of the read-out at that concentration, not a potency): 100%
Estimate against measurement, compound 4: no gap at the digits printed; measured number inside the range.
By their numbers in this assay, from the lowest: compounds 1, 3, 4 and 2 (each within the scatter of the next).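

The step of no change at the digits printed from compound 1 to compound 4 (within the scatter) in this assay comes from fluoro in place of hydrogen on an aromatic carbon, meta to a methyl group and para to a large group. The earlier steps shown here changed the group at the methyl site, whereas this one shows that a second place on the same ring also takes a small substituent with no change beyond the scatter. No measurement here offers an explanation for this result.

From the compounds shown here alone, whether an amine, a carboxylic acid or a longer chain at this place would move the number remains open. So does the effect of fluoro elsewhere on the ring.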